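Methyl added to the ethenyl linker of compound 2

A few compounds are considered here, and "the series" means these few. Any claim that something is new, unique, unknown or untested is made for them only; others in the source may bear on it.

In a functional assay on KETR3 cells (Homo sapiens) for inhibition, read by MTT assay, with a stated time of 120 h (on this read-out lower numbers stand for stronger inhibition and higher numbers for weaker inhibition), compound 2 `CNC(=O)/C=C/c1ccc(NC(=O)Nc2ccc(Cl)c(C(F)(F)F)c2)cc1` gives 21200 nM and stands level with compound 1 `CC(NC(=O)/C=C/c1ccc(NC(=O)Nc2ccc(Cl)c(C(F)(F)F)c2)cc1)c1ccccc1` at 21200 nM on the digits shown. Compound 3 `CC1CN(C(=O)/C=C/c2ccc(NC(=O)Nc3ccc(Cl)c(C(F)(F)F)c3)cc2)CC(C)O1` gives > 50000 nM as a limit of the assay and not a number. Compound 4 `CNC(=O)/C=C(\C)c1ccc(NC(=O)Nc2ccc(Cl)c(C(F)(F)F)c2)cc1` carries 1-methyl-2-(methylcarbamoyl)ethenyl in place of 2-(methylcarbamoyl)ethenyl on an aromatic carbon. Among the compounds with values here, no measured step touches this site. The measured steps alter only the group on the amide-type nitrogen or carbonyl carbon: no change at the digits printed from compound 1 to compound 2 (within the scatter) against an at least 2.3-fold higher number from compound 1 to compound 3 (0.37 log units; beyond the scatter) and an at least 2.3-fold higher number from compound 2 to compound 3 (0.37 log units; beyond the scatter) in the same series. A small step is therefore expected, leaning to a higher number: a 1.2-fold higher number from compound 2 to compound 4 (0.07 log units; within the scatter) is the expected step in this assay here. The estimate for compound 4 is 25000 nM with an expected range from 11000 nM to 50000 nM in this read-out.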

Compound 4, half-maximal inhibitory concentration: > 50000 nM
Compound 4 gave a limit, no number; the forecaster's own chance of this, stated with the estimate: 25%; middle value at least 2.0-fold (0.30 log units) from the limit.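

In this assay, 1-methyl-2-(methylcarbamoyl)ethenyl in place of 2-(methylcarbamoyl)ethenyl on an aromatic carbon gives an at least 2.3-fold higher number from compound 2 to compound 4 (0.37 log units; beyond the scatter). Within the data shown here, the earlier steps alter only the group on the amide-type nitrogen or carbonyl carbon, so this is the first sign that the linker also responds, here to one added methyl. The step gives a minimum and not a size, as the value of compound 4 is a limit: the limit of > 50000 nM in this assay, at which 2 of the 4 values shown sit.

On these data alone, whether an ethyl group or a fluorine in place of the added methyl gives the same result stays open. Also open, as far as these compounds go, is whether the added methyl has the same effect on the 1-phenylethyl amide of compound 1.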